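Acetyl removal on a diterpenoid lactone series: expected cytotoxicity

The source may hold more compounds than are shown below. What is called first, only, known or untested is meant among the compounds shown, and "the series" means these compounds.

The study compares three measured compounds and one not yet measured in a functional assay on KB cells (Homo sapiens) for cytotoxicity, read by sulforhodamine B assay; a lower number here means that less compound is needed, a higher number that more compound is needed for the effect. Compound 1 `C=C1CC[C@@H]2[C@](C)(CO)[C@H](OC(C)=O)CC[C@@]2(C)[C@@H]1C/C=C1/C(=O)OC[C@H]1O` gives 35.7 uM. Compound 2 `C=C1CC[C@@H]2[C@](C)(CO)[C@H](OC(C)=O)CC[C@@]2(C)[C@@H]1C/C=C1/C(=O)OC[C@H]1OC(C)=O` gives 11.7 uM. Compound 3 `C=C1CC[C@@H]2[C@](C)(CO[Si](C)(C)C(C)(C)C)[C@H](O)CC[C@@]2(C)[C@@H]1C/C=C1/C(=O)OC[C@H]1OC(C)=O` gives 10.7 uM. The two measured pairs show one counted step: a 3.1-fold higher number from compound 2 to compound 1 (0.48 log units; beyond the scatter), described by hydrogen in place of acetyl on an oxygen on a saturated carbon. How the core of compound 3 differs from the core of compound 2 is not broken down here; the two values for compound 2 and compound 3 lie within the scatter of each other, so nothing about order can be said for that pair.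

Compound 4 `C=C1CC[C@@H]2[C@](C)(CO[Si](C)(C)C(C)(C)C)[C@H](O)CC[C@@]2(C)[C@@H]1C/C=C1/C(=O)OC[C@H]1O` has not yet been measured in this assay. For the measured compounds named here, it differs from compound 3 by hydrogen in place of acetyl on an oxygen on a saturated carbon, which is the same change, at the same kind of place, as the one from compound 2 to compound 1. On that single measured step, a 3.1-fold higher number from compound 2 to compound 1 (0.48 log units; beyond the scatter), the account expects a step of similar size and direction for compound 4: a 3.0-fold higher number from compound 3 to compound 4 (0.48 log units; beyond the scatter) is the estimated change. Going by the values given here, because the only precedent is a 3.1-fold higher number from compound 2 to compound 1 (0.48 log units; beyond the scatter), and because the starting value for compound 3 is 10.7 uM, compound 4 is expected to give about 32 uM in this assay, with a plausible range from 15 uM to 70 uM.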

Compound 4, concentration for half-maximal effect: 40.7 uM
Compound 4: middle estimate off by 1.3-fold (0.10 log units), on the low side, within the range that was stated.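

In this assay, exchanging acetoxy for hydroxy on the core of compound 3 gives a 3.8-fold higher number from compound 3 to compound 4 (0.58 log units; beyond the scatter) and so repeats what was seen on the core of compound 2. Set side by side, the two steps point the same way and do not differ in size: the same change on two cores in this assay, a 3.1-fold higher number (0.48 log units; beyond the scatter) from compound 2 to compound 1 and a 3.8-fold higher number (0.58 log units; beyond the scatter) from compound 3 to compound 4, 1.2-fold (0.10 log units) apart, within the scatter of two such steps. Within this series, the change therefore carries over from one core to the other, but this rests on only two pairs in a single cell assay, and it shows neither why the acetyl group makes this difference nor that the step would keep its size on any core beyond these two.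

The compounds shown leave open whether a longer ester on that oxygen, such as a propionate or a benzoate, would read like the acetate, and whether an ether or an amine at the same place would read like the hydroxy compounds. They also leave open what each of the other differences between the two cores contributes on its own, including the silyl ether on one core and the free primary alcohol on the other.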